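Notes on an amide series: hydroxy to trifluoromethyl

The compounds below may be only part of what the source reports. "The series", "measured", "known", "first", "only" and "open" are said of these compounds alone.

Measured so far:
compound 1 `O=C(Nc1ccccc1O)C1CCc2ccccc2N1C(=O)c1ccccc1Cl` gives 44200 nM
compound 2 `O=C(Nc1ccccc1O)C1CCc2ccccc2N1C(=O)c1ccc(Cl)cc1` gives 19600 nM

Compound 1 stands as the higher of the two numbers in a functional assay on ACHN cells (Homo sapiens) for cytotoxicity, read by sulforhodamine B assay, with a stated time of 72 h; on this read-out higher numbers stand for weaker inhibition of growth and lower numbers for stronger inhibition of growth; compound 2 sits lower by a 2.3-fold lower number from compound 1 to compound 2 (0.35 log units; beyond the scatter), a change on the carbonyl side of the shared core only.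

Compound 3 `O=C(Nc1ccccc1C(F)(F)F)C1CCc2ccccc2N1C(=O)c1ccccc1Cl` keeps the chlorophenyl of compound 1 and changes the other aryl: trifluoromethyl in place of hydroxy on an aromatic carbon. Among the compounds with values here, no measured step touches this part of the molecule; the one known step, from compound 1 to compound 2, concerns the carbonyl aryl and says nothing about the hydroxy group. Within the data shown here, the expectation therefore rests on the single value of compound 1 alone, and no step beyond the scatter is expected in either direction. For compound 3 the number is estimated at 40000 nM, within 10000 nM to 160000 nM, an expected step of a 1.1-fold lower number from compound 1 to compound 3 (0.04 log units; within the scatter).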

Compound 3, concentration for 50% growth inhibition: 3900 nM
Estimate against measurement, compound 3: 10-fold (1.01 log units) above, outside the stated range (below it).
By their numbers in this assay, from the lowest: compound 3; then compound 2; then compound 1.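

In this assay, 2-(trifluoromethyl)phenyl in place of 2-hydroxyphenyl gives an 11-fold lower number from compound 1 to compound 3 (1.05 log units; beyond the scatter), so the substituent at this position has a strong bearing on the read-out. The earlier pair varied only the chlorophenyl on the carbonyl and left this position untouched; of the two steps now starting at compound 1, this one is the larger, against a 2.3-fold lower number from compound 1 to compound 2 (0.35 log units; beyond the scatter). Nothing on hand accounts for the size of the step.

A single replacement does not separate the entry of trifluoromethyl from the departure of hydroxy, and a methyl group, a chlorine atom or an amine at the same place would help to tell these apart. On these data alone, whether the step carries over to the 4-chlorophenyl of compound 2 also remains open.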